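Two measured compounds and one still awaiting its number

The source may report more compounds than this note shows. Statements on the series, on what has been measured and on what is new or still open speak of the compounds shown alone.

Compound 1: `O=C1C(c2ccccc2)CC(c2ccccc2)C(=O)N1Cc1ccccc1`, 14 mg/kg
Compound 2: `O=C1C(c2ccccc2Cl)CC(c2ccccc2Cl)C(=O)N1Cc1ccccc1`, 38.3 mg/kg

In a functional assay on the whole organism (strain Swiss albino) with Mus musculus as the target, in the maximal electroshock model, with a stated time of 2 h (on this read-out lower numbers stand for an effect already at smaller amounts and higher numbers for an effect only at larger amounts of compound), compound 1 gives 14 mg/kg. In this assay compound 2 gives 38.3 mg/kg, the highest of the two numbers shown; the gap from compound 1 to compound 2 lies beyond the usual scatter of such measurements. Compound 3, `Cc1ccc(N2C(=O)C(c3ccccc3Cl)CC(c3ccccc3Cl)C2=O)cc1`, differs from compound 2 by a single exchange: 4-methylphenyl in place of benzyl on an amide-type nitrogen in a ring. For the measured compounds named here, no pair of measured compounds differs in just this way, so this exchange has no measured step of its own here. Without such a reference, the change from compound 2 to compound 3 is expected to move the number by no more than the usual scatter, with the step of a 1.0-fold higher number from compound 2 to compound 3 (0.02 log units; within the scatter) as the estimate. For compound 3 the expected value in this assay is 40 mg/kg, within a range from 15 mg/kg to 110 mg/kg.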

Compound 3, dose for half-maximal effect: 41.2 mg/kg
Compound 3: the middle estimate sits 1.0-fold (0.01 log units) below what was measured; the range from low to high includes it.
By their numbers in this assay, from the lowest: compound 1; then compounds 2 and 3 (each within the scatter of the next).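

On the amide-type nitrogen in a ring, with both 2-chlorophenyl groups in place, the exchange of benzyl for 4-methylphenyl gives a 1.1-fold higher number from compound 2 to compound 3 (0.03 log units; within the scatter) in this assay. For the compounds shown here, this is the first single-place comparison, and it shows that at this position, two groups with the same count of heavy atoms and one six-membered aromatic ring each, but joined differently, cannot be told apart on this read-out.

From the compounds shown here alone, it remains open whether a group of another kind on this nitrogen, such as an amine, a carboxylic acid or a longer carbon chain, would read the same way. Going by these compounds, it is equally open whether the benzyl to 4-methylphenyl exchange would behave alike on the core of compound 1, which lacks the chlorine atoms. Nothing available here offers a reason for this result.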